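Butylsulfonyl replaces isopropylcarbonyl in compound 3

This account rests on a few compounds, and the source may have more. Where it says the series, first, only, none or still open, it means among the compounds named here.

Compound 1 `CCC(C)C(=O)N1CCC(NC(=O)Nc2ccc(C(F)(C(F)(F)F)C(F)(F)F)cc2)CC1`: 135 nM
Compound 2 `CCC(C)C(=O)N1CCC(NC(=O)N[C@H]2CC[C@H](CC)CC2)CC1`: 5 nM
Compound 3 `CC(C)C(=O)N1CCC(NC(=O)Nc2ccc(OC(F)(F)F)cc2)CC1`: 900 nM

In an ADME assay on the whole organism (strain Swiss Webster) for pharmacokinetics, with Mus musculus as the target, using cassette dosing, at a dose of 0.3 mg/kg by the oral route (a higher number here means more compound in the circulation at the dose given, a lower number less compound in the circulation), compound 3 stands highest of the three, with compound 1 and compound 2 both lower by more than the scatter. Compound 4 `CCCCS(=O)(=O)N1CCC(NC(=O)Nc2ccc(OC(F)(F)F)cc2)CC1` has not yet been measured. It carries butylsulfonyl in place of isopropylcarbonyl on an amine nitrogen in a ring. For the measured compounds named here, no measured pair shows a change of this kind, so the expectation rests on little. Compound 3 at 900 nM sits at the top of the measured range, which makes a fall more likely than a rise. The expected change, beyond the scatter and downward, is a 3.6-fold lower number from compound 3 to compound 4 (0.56 log units; beyond the scatter) in this estimate. For compound 4 the estimated maximal plasma concentration is 250 nM within an expected range of 60 nM to 800 nM in this assay when it is measured.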

Compound 4, maximal plasma concentration in the Mus musculus assay: 65 nM
The estimate for compound 4 lay 3.8-fold (0.59 log units) above the measured number, within the range that was stated.
By their numbers in the Mus musculus assay, from the lowest: compound 2; then compound 4; then compound 1; then compound 3.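

For the compounds shown here, this step is the first at this position with the rest of the molecule held constant, and it shows that the position is far from silent: in the Mus musculus assay, butylsulfonyl in place of isopropylcarbonyl on an amine nitrogen in a ring gives a 14-fold lower number from compound 3 to compound 4 (1.14 log units; beyond the scatter). The fall in circulating compound may owe something to solubility, because that drops as well in a physicochemical assay for solubility, in phosphate buffer, at pH 7.4; a higher number here means a more soluble compound, a lower number a less soluble compound: the measured solubility of compound 3, 27 ug/mL, and of compound 4, 0.6 ug/mL, a 45-fold lower number (1.65 log units; beyond the scatter) In the physicochemical assay compound 3 gives 27 ug/mL and compound 4 gives 0.6 ug/mL.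

The compounds shown change the linking group and the chain together, so they leave open which of the two carries the step. An isopropylsulfonyl or a butylcarbonyl group on the same nitrogen would separate them.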